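The source may hold more compounds than are shown below. What is called first, only, known or untested is meant among the compounds shown, and "the series" means these compounds.

Compound 2 `Cc1ccccc1-c1nn(-c2ccc(F)cc2F)cc1CNCCCCO` was examined in an ADME assay on Huh-7 cells (Homo sapiens) for cytotoxicity; on this read-out higher numbers stand for lower toxicity in this test and lower numbers for higher toxicity in this test. In this assay compound 2 reaches only a limit, > 20000 nM, and no number. Its reading sits at the limit of > 20000 nM in this assay, at which 1 of the 3 values shown sits. For comparison, compound 1 `CN1CCN(CCCNCc2cn(-c3ccc(C(F)(F)F)cc3)nc2-c2ccc(OC(F)(F)F)cc2)CC1` gives 2300 nM in this assay, and compound 3 `CN1CCN(CCNCc2cn(-c3ccc(F)cc3F)nc2-c2ccc(Cl)cc2)CC1` gives 19000 nM. Compound 4 `Cc1ccccc1-c1nn(-c2ccc(F)cc2F)cc1CNCCN(C)C` has not yet been measured. It differs from compound 2 in one place: dimethylamino in place of 2-hydroxyethyl on a saturated chain carbon, two bonds along the chain from an amine nitrogen. Within the data shown here, no step between two measured compounds is available, so the size of the change can only be expected, not read off. The step of an at least 1.6-fold lower number from compound 2 to compound 4 (0.22 log units; that floor lies within the scatter) is estimated to run toward higher toxicity, though it may not exceed the usual scatter. Compound 4 is expected to give 12000 nM, within a range from 4000 nM to 30000 nM.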

Compound 4, half-maximal cytotoxic concentration: > 20000 nM
Compound 4 gave a limit, no number (the forecaster's own chance of this, stated with the estimate: 35%); middle value at least 1.6-fold (0.22 log units) from the limit.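

In this assay, among these compounds, compound 2 and compound 4 both give only a limit, so no step between them can be read: the limit of > 20000 nM in this assay, at which 2 of the 4 values shown sit.

In this assay the compounds shown leave open whether dimethylamino in place of 2-hydroxyethyl shifts the reading at all.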